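Aryl swap on the ring nitrogen: outlook for compound 4

The source may report more compounds than this note shows. Statements on the series, on what has been measured and on what is new or still open speak of the compounds shown alone.

Compound 1 `N#CC1=C(N)Oc2c(N)cc3nc4ccccc4nc3c2C12C(=O)N(Cc1cnnn1-c1ccc(F)cc1)c1ccccc12` in a functional assay on HepG2 cells (Homo sapiens) for antiproliferative activity, read by MTT assay, with a stated time of 48 h (on this read-out lower numbers stand for stronger inhibition and higher numbers for weaker inhibition), gives > 50000 nM, which is a limit of the assay.
Compound 2 `COc1ccc(-n2nncc2CN2C(=O)C3(C(C#N)=C(N)Oc4c(N)cc5nc6ccccc6nc5c43)c3ccccc32)cc1` in this assay gives > 50000 nM, also a limit of the assay.
Compound 3 `CCOc1ccccc1-n1nncc1CN1C(=O)C2(C(C#N)=C(N)Oc3c(N)cc4nc5ccccc5nc4c32)c2ccccc21` in this assay gives 30500 nM.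

Among the measured compounds shown here, compound 3 thus holds the only number in this assay; the other two values are limits, as the limit of > 50000 nM in this assay, at which 2 of the 3 values shown sit, records. The steps leading to it read an at least 1.6-fold lower number from compound 1 to compound 3 (0.21 log units; that floor lies within the scatter) and an at least 1.6-fold lower number from compound 2 to compound 3 (0.21 log units; that floor lies within the scatter); both floors lie within the scatter, so the measured steps show no change in this assay that can be called real.

Compound 4 `N#CC1=C(N)Oc2c(N)cc3nc4ccccc4nc3c2C12C(=O)N(Cc1cnnn1-c1c(F)cccc1F)c1ccccc12` differs from compound 3 by 2,6-difluorophenyl in place of 2-ethoxyphenyl on an aromatic nitrogen. For the measured compounds named here, no measured step covers a 2,6-difluorophenyl on this nitrogen. The two steps that bear on it, an at least 1.6-fold lower number from compound 1 to compound 3 (0.21 log units; that floor lies within the scatter) and an at least 1.6-fold lower number from compound 2 to compound 3 (0.21 log units; that floor lies within the scatter), both carry a fluoro- or methoxy-bearing aryl into the 2-ethoxyphenyl, and both sit within the scatter; compound 4 goes the other way, removing the ethoxy, so no step beyond the scatter is expected in this assay in either direction, with a real chance that the assay again returns only a limit. Compound 4 is therefore expected at 42000 nM in this assay, with a range from 15000 nM to 120000 nM. This estimate means a step of a 1.4-fold higher number from compound 3 to compound 4 (0.14 log units; within the scatter) in this assay, which stays within the scatter.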

Compound 4, half-maximal inhibitory concentration: > 50000 nM
Compound 4: no number, only a limit; the forecaster's own chance of this, stated with the estimate: 55%; middle value at least 1.1-fold (0.07 log units) from the limit.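

Among the compounds shown here, compound 4 is a third aryl variant on this aromatic nitrogen to stop at a limit in this assay, and the 2,6-difluorophenyl adds a doubly substituted aryl carrying no ethoxy to the two singly substituted aryls already at that limit: the limit of > 50000 nM in this assay, at which 3 of the 4 values shown sit. Compound 3 thus remains the only compound of the four with a number, yet the one readable new step is an at least 1.6-fold higher number from compound 3 to compound 4 (0.21 log units; that floor lies within the scatter), so the exchange of 2-ethoxyphenyl for 2,6-difluorophenyl cannot be called a real change. The steps to compound 4 from compound 1 and from compound 2 cannot be read, each having a limit at both ends, so nothing orders the three aryl groups at the limit.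

Going by these compounds, whether the 2-ethoxyphenyl carries any real advantage stays open, and an answer would need a step beyond the scatter from a neighbouring group on the same nitrogen, such as 2-methoxyphenyl or 2-butoxyphenyl. Also open, on these data alone, is whether an aryl bearing an amine or a carboxylic acid at this nitrogen would give a clear number in this assay.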